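Changing the Amide Aryl on a Shared Core

This account rests on a few compounds, and the source may have more. Where it says the series, first, only, none or still open, it means among the compounds named here.

Three compounds sharing one core were tested in an assay on isolated protein for inhibition of RAC-alpha serine/threonine-protein kinase (Homo sapiens), read by fluorescence, with a stated time of 30 min, tested at 10 uM; on this read-out lower numbers stand for less inhibition and higher numbers for more inhibition at the one concentration tested (going by the name of the read-out). Compound 1 `O=C(Nc1cc(Sc2ncn[nH]2)c(O)c2ccccc12)c1cccc([N+](=O)[O-])c1` gives 29.3%, the highest of the three numbers as they stand. Compound 3 `O=C(Nc1cc(Sc2ncnc3nc[nH]c23)c(O)c2ccccc12)c1ccc(Cl)cc1` gives 21.7%, which lies within the scatter of compound 1, while compound 2 `Cc1nnc(Sc2cc(NC(=O)c3ccc(Cl)cc3)c3ccccc3c2O)s1` gives 8.48%, beyond it. Among the compounds with values here, the one measured step, a number 13.2 percentage points higher from compound 2 to compound 3 (beyond the scatter), alters the ring on the sulfur and leaves the amide side untouched. Within the data shown here, compound 4 `COc1ccc(C(=O)Nc2cc(Sc3ncn[nH]3)c(O)c3ccccc23)cc1` differs from compound 1 by 4-methoxyphenyl in place of 3-nitrophenyl on a carbonyl carbon, a change on the amide side for which no measured step exists. With nothing pointing either way, compound 4 is expected to show a step of a number 4.3 percentage points lower from compound 1 to compound 4 (within the scatter) that stays within the scatter. Compound 4 is therefore estimated at 25%, within a range of 8% to 42%.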

Compound 4, a percentage reported as inhibition, at one concentration (the size of the read-out at that concentration, not a potency): 30.8%
Beside the measured number, compound 4's estimate is 5.8 percentage points below it, within the range that was stated.
By their numbers in this assay, from the lowest: compound 2; then compounds 3, 1 and 4 (each within the scatter of the next).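

Within the data shown here, putting 4-methoxyphenyl in place of 3-nitrophenyl on a carbonyl carbon gives a number 1.5 percentage points higher from compound 1 to compound 4 (within the scatter), the first measured step on the amide side, as the earlier step altered only the ring on the sulfur. At the one concentration tested, this assay therefore does not separate these two aryl groups. Nothing available explains why the two compounds read alike. From the compounds shown here alone, it remains open whether an amine or a carboxylic acid on this aryl ring would give a step beyond the scatter. Also open, going by these compounds, is whether 4-methoxyphenyl would read the same with the ring on the sulfur of compound 3.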